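Swapping an Amino for a Fluoro on the Aryl Ring

A few compounds are considered here, and "the series" means these few. Any claim that something is new, unique, unknown or untested is made for them only; others in the source may bear on it.

Compounds measured so far:
- compound 1, `COC(=O)C1=C(C)N=C(C)/C(=C(\O)OC)C1c1cc([N+](=O)[O-])ccc1O`: 100 nM
- compound 2, `COC(=O)C1=C(C)N=C(C)/C(=C(\O)OC)C1c1cccc(N)c1`: 2000 nM

Both compounds share one core and differ only in the aromatic ring attached to it. In a functional assay (muscle tissue) with Cavia porcellus as the target (on this read-out lower numbers stand for an effect already at smaller amounts and higher numbers for an effect only at larger amounts of compound), compound 1 gives 100 nM, while compound 2 gives 2000 nM. Compound 2 thus stands at the higher of the two numbers, and the gap to compound 1 lies well beyond the usual scatter, so compound 2 is the weaker of the pair.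

The next compound, compound 3, `COC(=O)C1=C(C)N=C(C)/C(=C(\O)OC)C1c1cccc(F)c1`, keeps the core of compound 2 and changes a single spot on its aromatic ring: fluoro in place of amino on an aromatic carbon. Among the compounds with values here, no measured pair shows exactly this exchange, so the size of its effect must be guessed. On this assay a moderate shift toward a lower number is expected, estimated as a 5.0-fold lower number from compound 2 to compound 3 (0.70 log units; beyond the scatter). Compound 3 is therefore expected to give about 400 nM, within a range of 100 nM to 1500 nM.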

Compound 3, half-maximal effective concentration: 20.9 nM
For compound 3 the middle estimate is 19-fold (1.28 log units) above the measured one; measured number below the stated range.
By their numbers in this assay, from the lowest: compound 3; then compound 1; then compound 2.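

In this assay, fluoro in place of amino on this aromatic carbon gives a 96-fold lower number from compound 2 to compound 3 (1.98 log units; beyond the scatter), so exchanging a single heavy atom at this one spot on the ring is enough for a large step. The two earlier compounds could not show this, since their rings differ in more than one place and no change could be tied to a single position. Nothing measured here speaks to why the step is so large.

The compounds shown leave open whether the step belongs to the arrival of fluoro or to the departure of amino, which a plain hydrogen, a chloro or a methoxy at the same place could help separate. Going by these compounds, how a larger group, such as trifluoromethyl or a nitrile, would fare there also remains open.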